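Swapping the Amide Aryl Group Toward a Nitrophenyl

This account rests on a few compounds, and the source may have more. Where it says the series, first, only, none or still open, it means among the compounds named here.

Compound 2 `O=C(Nc1cccc(-c2oc3cc(-c4ccc(F)cc4)ccc3c(=O)c2O)c1)c1ccc(Cl)nc1` holds the lowest of the two numbers seen so far: in a functional assay on MCF7 cells (Homo sapiens) for antiproliferative activity, read by CCK-8 assay, with a stated time of 72 h (a higher number here means a weaker inhibitor, a lower number a stronger inhibitor), compound 2 gives 2890 nM, while compound 1 `O=C(Nc1cccc(-c2oc3cc(-c4ccc(F)cc4)ccc3c(=O)c2O)c1)c1ccc(F)cc1F` gives 13500 nM. Within the data shown here, the single measured step, a 4.7-fold lower number from compound 1 to compound 2 (0.67 log units; beyond the scatter), also changed the group on the carbonyl carbon. Compound 3 `O=C(Nc1cccc(-c2oc3cc(-c4ccc(F)cc4)ccc3c(=O)c2O)c1)c1ccc([N+](=O)[O-])cc1` carries the change (4-nitrophenyl in place of 6-chloropyridin-3-yl on a carbonyl carbon). One step on a different pair of groups gives little guidance, so the step expected here, a 1.4-fold higher number from compound 2 to compound 3 (0.14 log units; within the scatter), is small and may stay within the scatter. Compound 3 is therefore estimated at 4000 nM, ranging from 1500 nM to 11000 nM.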

Compound 3, half-maximal inhibitory concentration: 3970 nM
Compound 3: the middle estimate sits 1.0-fold (0.00 log units) above what was measured; low and high end bracket the measured number.
By their numbers in this assay, from the lowest: compounds 2 and 3 (each within the scatter of the next); then compound 1.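

In this assay, the change gives a 1.4-fold higher number from compound 2 to compound 3 (0.14 log units; within the scatter), so 4-nitrophenyl and 6-chloropyridin-3-yl on this carbonyl carbon cannot be told apart, although one ring is carbon only and the other holds a hetero atom. Against 2,4-difluorophenyl, the record shows a 3.4-fold lower number from compound 1 to compound 3 (0.53 log units; beyond the scatter), so the gap to compound 1 no longer rests on a single replacement. No measurement here explains why these groups compare as they do. Still open, as far as these compounds go, is how an amine, a carboxylic acid or a saturated ring such as piperidine would compare on this carbonyl carbon.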